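Swapping the amide ring from compound 3 to compound 4

The source may hold more compounds than are shown below. What is called first, only, known or untested is meant among the compounds shown, and "the series" means these compounds.

In a functional assay on HeLa cells (Homo sapiens) for antiproliferative activity, read by MTT assay, with a stated time of 72 h (a higher number here means a weaker inhibitor, a lower number a stronger inhibitor), compound 3 (`O=C(Nc1ccc(Cl)c(-c2nnc3c(Cl)cccn23)c1)c1cccnc1`) reads > 100000 nM, which is a limit. Within the data shown here, compound 2 (`O=C(Nc1ccc(Cl)c(-c2nnc3c(Cl)cccn23)c1)c1ccccn1`) gives 75500 nM, the only true number so far. Among the measured compounds shown here, compound 1 (`O=C(Nc1ccc(Cl)c(-c2nnc3c(Cl)cccn23)c1)c1ccc(C(F)(F)F)cc1Cl`), the one measured member with a carbon-only ring on that carbonyl carbon, reads > 100000 nM, also a limit.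

Compound 4 (`Cc1cc(Cl)ccc1C(=O)Nc1ccc(Cl)c(-c2nnc3c(Cl)cccn23)c1`) has 4-chloro-2-methylphenyl in place of pyridin-3-yl on a carbonyl carbon. For the measured compounds named here, the only measured step, an at least 1.3-fold higher number from compound 2 to compound 3 (0.12 log units; that floor lies within the scatter), is a swap of pyridine isomers and gives little guidance. The closest reference is the limit of > 100000 nM in this assay, at which 2 of the 3 values shown sit. No change beyond the scatter is expected in this assay, so the expected step is a number no higher from compound 3 to compound 4 (the limit leaves the size open). For compound 4 the estimated value is 100000 nM, with an expected range of 50000 nM to 200000 nM.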

Compound 4, half-maximal inhibitory concentration: > 100000 nM
Compound 4 ended at the assay's limit; the forecaster's own chance of this, stated with the estimate: 65%; the middle value sits exactly at the limit.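

In this assay compound 4 gives a limit, so its step from compound 3, also a limit, cannot be read. Among these compounds, the only readable comparison is an at least 1.3-fold higher number from compound 2 to compound 4 (0.12 log units; that floor lies within the scatter), so no change beyond the scatter is established on this carbonyl carbon, even with 4-chloro-2-methylphenyl, a ring of carbon only. The series now clusters at one limit: the limit of > 100000 nM in this assay, at which 3 of the 4 values shown sit.

Open, as far as these compounds go, is whether an amine or a carboxylic acid on this carbonyl carbon would give a true number in this assay. From the compounds shown here alone, how far compound 1, compound 3 and compound 4 lie past the limit also stays unknown.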